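Substituting the amide nitrogen of the series

The source may hold more compounds than are shown below. What is called first, only, known or untested is meant among the compounds shown, and "the series" means these compounds.

In a functional assay on HCT-116 cells (Homo sapiens) for antiproliferative activity, read by MTT assay, with a stated time of 72 h (on this read-out higher numbers stand for weaker inhibition and lower numbers for stronger inhibition), compound 1 `C=CC(=O)Nc1nc(-c2ccccc2)cs1` gives 18600 nM and lies within the scatter of compound 3 `C=CC(=O)Nc1nc(-c2ccccc2F)cs1` at 20400 nM while compound 2 `C=CC(=O)Nc1nc(-c2ccc(OC)cc2)cs1` gives a lower 8000 nM in this set of three. Compound 4 `C=CC(=O)N(CC(=O)OCC)c1nc(-c2ccccc2)cs1` has (ethoxycarbonyl)methyl in place of hydrogen on the amide-type nitrogen of compound 1 ((ethoxycarbonyl)methyl in place of hydrogen on an amide-type nitrogen). Among the measured compounds shown here, the only step beyond the scatter, a 2.3-fold lower number from compound 1 to compound 2 (0.37 log units; beyond the scatter) with methoxy, is modest, and a 1.1-fold higher number from compound 1 to compound 3 (0.04 log units; within the scatter) with fluoro stays within it. Both sit on an aromatic carbon, not on this nitrogen, so they bear only indirectly. No direction can be read from them, and the expected change, a 1.2-fold lower number from compound 1 to compound 4 (0.07 log units; within the scatter) in the estimate, stays within the scatter. Compound 4 is estimated at 16000 nM with a range from 5000 nM to 50000 nM expected.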

Compound 4, half-maximal inhibitory concentration: > 30000 nM
Compound 4: no number, only a limit (the forecaster's own chance of this, stated with the estimate: 10%); at least 1.8-fold (0.27 log units) between middle value and limit.
By their numbers in this assay, from the lowest: compound 2; then compounds 1 and 3 (each within the scatter of the next). At a limit, above all of these: compound 4.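

In this assay compound 4 gives no number, only a limit of the assay: the limit of > 30000 nM in this assay, at which 1 of the 4 values shown sits. Read against that limit, the step is an at least 1.6-fold higher number from compound 1 to compound 4 (0.20 log units; that floor lies within the scatter), so (ethoxycarbonyl)methyl on the amide-type nitrogen brings no lower number, although the floor of the change stays within the scatter. Among the compounds shown here, the earlier steps sat on an aromatic carbon, so this is the only reading at this nitrogen.

As far as these compounds go, whether compound 4 truly lies beyond the scatter of compound 1 remains open. Also open, from the compounds shown here alone, is whether a methyl, or a carboxylic acid in place of the ethyl ester, on this nitrogen would give a measurable number.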